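The source may report more compounds than this note shows. Statements on the series, on what has been measured and on what is new or still open speak of the compounds shown alone.

Three sulfonamides were tested in an ADME assay on HEK293 cells (Homo sapiens) for cytotoxicity, read by resazurin assay, with a stated time of 48 h; a lower number here means that less compound is tolerated, a higher number that more compound is tolerated. Compound 1 `O=S(=O)(Nc1ccc2oc(-c3ccccc3)nc2c1)c1ccc(Cl)c(Cl)c1` gives 71000 nM. Compound 2 `O=S(=O)(Nc1ccc(-c2nc3ccccc3o2)cc1)c1ccccc1O` reaches only a limit of the assay, > 100000 nM. Compound 3 `O=S(=O)(Nc1ccc2oc(-c3ccccc3)nc2c1)c1cccc(C(F)(F)F)c1` likewise reaches only a limit, > 100000 nM. Compound 3 thus stands at the limit of > 100000 nM in this assay, at which 2 of the 3 values shown sit, and carries no number of its own. Compound 4 `O=S(=O)(Nc1ccc2oc(-c3ccccc3)nc2c1)c1ccc(Cl)c(C(F)(F)F)c1` differs from compound 3 by chloro in place of hydrogen on an aromatic carbon. Among the compounds with values here, no step between two measured compounds that differ in one place is available to guide the expectation. The step from compound 3 to compound 4 in this assay is expected to be none beyond the scatter, an at least 1.1-fold lower number from compound 3 to compound 4 (0.04 log units; that floor lies within the scatter). The estimate for compound 4 in this assay is 90000 nM, with a range from 45000 nM to 180000 nM.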

Compound 4, half-maximal cytotoxic concentration: 66000 nM
Compound 4: middle estimate off by 1.4-fold (0.13 log units), on the high side; low and high end bracket the measured number.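

Chloro on this aromatic carbon, ortho to a trifluoromethyl group, brings a measurable number in this assay, and the step is an at least 1.5-fold lower number from compound 3 to compound 4 (0.18 log units; that floor lies within the scatter). On these data alone, compound 3 holds only a limit, so the true size of this step stays unknown: the limit of > 100000 nM in this assay, at which 2 of the 4 values shown sit. Trifluoromethyl in place of chloro on the neighbouring substituted carbon of compound 1 is not told apart from it, the step being a 1.1-fold lower number from compound 1 to compound 4 (0.03 log units; within the scatter).

Open, as far as these compounds go, is how an amine or a carboxylic acid on this same aromatic carbon would read in this assay. From the compounds shown here alone, a methyl group or a methoxy group there is equally open.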